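This account rests on a few compounds, and the source may have more. Where it says the series, first, only, none or still open, it means among the compounds named here.

Compound 1 `O=c1[nH]cc(S(=O)(=O)Nc2ccccc2-c2cn(-c3ccccc3F)nn2)c(=O)[nH]1`: 10800 nM
Compound 2 `O=c1[nH]cc(S(=O)(=O)Nc2ccc(-c3cn(-c4ccccc4F)nn3)cc2)c(=O)[nH]1`: 7270 nM

Of the compounds shown here, two have been measured in a functional assay on SGC-7901 cells (Homo sapiens) for antiproliferative activity, read by MTT assay, with a stated time of 24 h; a higher number here means a weaker inhibitor, a lower number a stronger inhibitor. Compound 1 gives 10800 nM and compound 2 gives 7270 nM. Compound 2 has the lower of the two numbers, but its gap to compound 1 lies within the usual scatter of repeated measurements, so the two cannot be told apart with confidence. Compound 3 `O=c1[nH]cc(S(=O)(=O)Nc2ccc(-c3cn(-c4ccc(Cl)cc4)nn3)cc2)c(=O)[nH]1` has not yet been measured. It differs from compound 2 in one place: 4-chlorophenyl in place of 2-fluorophenyl on an aromatic nitrogen. Among the measured compounds shown here, no pair of measured compounds shows what such an exchange does in this assay, so there is nothing to lean on beyond the two values themselves. An exchange of one substituted phenyl for another of the same size is expected to move the number little, if at all, beyond the scatter. Compound 3 is expected at about 6000 nM, with a range from 2500 nM to 15000 nM. This estimate means a step of a 1.2-fold lower number from compound 2 to compound 3 (0.08 log units; within the scatter), expected to stay within the scatter.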

Compound 3, half-maximal inhibitory concentration: 1830 nM
For compound 3 the middle estimate is 3.3-fold (0.52 log units) above the measured one; the whole stated range lies above it.
By their numbers in this assay, from the lowest: compound 3; then compounds 2 and 1 (each within the scatter of the next).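

In this assay, 4-chlorophenyl in place of 2-fluorophenyl on the aromatic nitrogen gives a 4.0-fold lower number from compound 2 to compound 3 (0.60 log units; beyond the scatter), so this position is not indifferent to which substituted phenyl it carries. The two groups match in heavy-atom count, in having one six-membered aromatic ring of carbon only, in having no hydrogen-bond donors or acceptors and in having no net charge, so these counts alone do not separate them, yet the number still moves. No measurement shown here says why.

Both the halogen and its place on the phenyl ring differ between compound 2 and compound 3, so the compounds shown cannot say which of the two matters, and 2-chlorophenyl or 4-fluorophenyl would be needed to pull them apart. As far as these compounds go, how an unsubstituted phenyl, or a phenyl bearing a methoxy group or an amine, would behave on this nitrogen also remains open.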